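The source may report more compounds than this note shows. Statements on the series, on what has been measured and on what is new or still open speak of the compounds shown alone.

Measured so far in a functional assay on HUVEC cells (Homo sapiens); on this read-out lower numbers stand for an effect already at smaller amounts and higher numbers for an effect only at larger amounts of compound: compound 1 `O=C(c1ccc(O)c(Br)c1)c1cc(O)c(O)cc1Br` gives 2000 nM; compound 2 `O=C(c1ccccc1)c1cc(O)c(O)cc1Br` gives 11500 nM; compound 3 `Oc1cc(Br)c(Cc2cc(Br)ccc2O)cc1O` gives 1100 nM.

Compound 2 stands highest of the three numbers, beyond the scatter from both compound 1 and compound 3. Compound 4 `O=C(c1ccccc1)c1cc(O)c(O)c(Br)c1Br` differs from compound 2 by bromo in place of hydrogen on an aromatic carbon, so that compound 4, like compound 1 and compound 3, carries two bromo groups. Among the compounds with values here, no directly comparable step between measured compounds exists. A move to a lower number in this assay is expected for compound 4, likely beyond the scatter, because compound 1 gives 2000 nM and compound 3 gives 1100 nM. The step from compound 2 to compound 4 implied by this estimate is a 2.3-fold lower number from compound 2 to compound 4 (0.36 log units; beyond the scatter). Compound 4 is estimated at 5000 nM, range 1500 nM to 15000 nM.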

Compound 4, half-maximal effective concentration: 800 nM
Estimate against measurement, compound 4: 6.3-fold (0.80 log units) above; the whole stated range lies above it.
By their numbers in this assay, from the lowest: compounds 4, 3 and 1 (each within the scatter of the next, the first and the last beyond it); then compound 2.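

In this assay, bromo in place of hydrogen on the aromatic carbon ortho to a bromo group and ortho to a hydroxy group gives a 14-fold lower number from compound 2 to compound 4 (1.16 log units; beyond the scatter) with nothing else changed. Within the data shown here, this is the first change that can be read at a single place, and it shows that this position responds strongly to bromo. Nothing measured here accounts for the size of this step.

From the compounds shown here alone, whether chloro, methyl or an amine at this position would give a similar step remains open. So does whether bromo here would have the same effect on the core of compound 1.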